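This account rests on a few compounds, and the source may have more. Where it says the series, first, only, none or still open, it means among the compounds named here.

Three amides built on one shared core have been tested in a functional assay on the whole organism (strain Swiss albino) for inhibition, with Mus musculus as the target, in the writhing test, with stated times of 60 min and 15 min, at a dose of 100 mg/kg by the oral route; on this read-out higher numbers stand for more inhibition at the one dose given (going by the name of the read-out) and lower numbers for less inhibition. Compound 1 `CCNC(=O)CC1CCc2cc(OC)c(OC)cc21` gives 23.6% in this assay. Compound 2 `CCCCNC(=O)CC1CCc2cc(OC)c(OC)cc21` gives 39.4%, and compound 3 `CCCCCCNC(=O)CC1CCc2cc(OC)c(OC)cc21` gives 82.2%. The steps between them all point one way: a number 15.8 percentage points higher from compound 1 to compound 2 (beyond the scatter), a number 42.8 percentage points higher from compound 2 to compound 3 (beyond the scatter) and a number 58.6 percentage points higher from compound 1 to compound 3 (beyond the scatter), each resting on a longer chain on the amide-type nitrogen. Compound 3 therefore stands highest of the three in this assay, with compound 2 nearest and compound 1 furthest below it, both gaps beyond the scatter.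

Compound 4 `COc1cc2c(cc1OC)C(CC(=O)N1CCNCC1)CC2` differs from compound 3 in one place: piperazin-1-yl in place of hexylamino on a carbonyl carbon. Among the compounds with values here, none of the measured steps covers this exchange directly; they only show that a shorter chain on the nitrogen went with a lower number. Since compound 4 carries no chain there at all, a fall in this assay is expected for compound 4, to an estimated 35% within 15% to 60%. That estimate means an expected step of a number 47.2 percentage points lower from compound 3 to compound 4 (beyond the scatter), though the ring could behave unlike any chain seen here.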

Compound 4, a percentage reported as inhibition, in the whole organism at one dose (the size of the read-out at that dose, not a potency): 68.8%
Compound 4: middle estimate off by 33.8 percentage points, on the low side; measured number outside the range, above it.
By their numbers in this assay, from the lowest: compound 1; then compound 2; then compound 4; then compound 3.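

On the carbonyl carbon, piperazin-1-yl does not fit the pattern set by the three chains: in this assay the exchange for hexylamino gives a number 13.4 percentage points lower from compound 3 to compound 4 (beyond the scatter), while the exchange for butylamino gives a number 29.4 percentage points higher from compound 2 to compound 4 (beyond the scatter) and the exchange for ethylamino gives a number 45.2 percentage points higher from compound 1 to compound 4 (beyond the scatter). A long open chain is thus not required for a high number at this position, as this six-membered non-aromatic ring ranks above butylamino and ethylamino, though still below hexylamino. Nothing available here accounts for the place of the ring among the chains.

The compounds shown leave open whether octylamino on the same carbonyl carbon would extend the rise seen along the chains. They also leave open how the second ring nitrogen figures in this result, a question that morpholin-4-yl or piperidin-1-yl in its place would address.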